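From pyridin-3-yl to oxetan-3-yl at the assay limit

A few compounds are considered here, and "the series" means these few. Any claim that something is new, unique, unknown or untested is made for them only; others in the source may bear on it.

- Compound 1 `CC(C)(C)C#Cc1cc(N(C(=O)[C@H]2CC[C@H](C)CC2)[C@H]2CC[C@H](Oc3cccnc3)CC2)c(C(=O)O)s1`: > 20000 nM (a limit)
- Compound 2 `CC(C)(C)C#Cc1cc(N(C(=O)[C@H]2CC[C@H](C)CC2)[C@H]2CC[C@](O)(CO[C@H]3CCOC3)CC2)c(C(=O)O)s1`: > 20000 nM (a limit)
- Compound 3 `CC(C)(C)C#Cc1cc(N(C(=O)[C@H]2CC[C@H](C)CC2)[C@H]2CC[C@@H](Oc3ccc(=O)[nH]n3)CC2)c(C(=O)O)s1`: > 20000 nM (a limit)

In an ADME assay on MT4 cells (Homo sapiens) for cytotoxicity, with a stated time of 5 days (on this read-out higher numbers stand for lower toxicity in this test and lower numbers for higher toxicity in this test), compound 1 gives > 20000 nM, which is a limit of the assay and not a number. As far as these compounds go, its true position therefore remains unknown. Compound 2 and compound 3 stand in the same place, and the set as a whole sits at the limit of > 20000 nM in this assay, at which 3 of the 3 values shown sit. No pair among these three compounds differs in one place alone, so no measured step is available as a guide.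

Compound 4 `CC(C)(C)C#Cc1cc(N(C(=O)[C@H]2CC[C@H](C)CC2)[C@H]2CC[C@H](OC3COC3)CC2)c(C(=O)O)s1` has not yet been measured in this assay. It differs from compound 1 in one place: oxetan-3-yl in place of pyridin-3-yl on an oxygen on a saturated carbon. In words, oxetan-3-yl stands in place of pyridin-3-yl on an oxygen on a saturated carbon.

The expectation rests on compound 1 at > 20000 nM, again a limit, and on the same result for the other two compounds. The expected change, a step that the limit leaves unreadable from compound 1 to compound 4, is estimated to stay within the scatter, with no clear direction. The assay may well report only a limit again. For compound 4 the estimated value is 22000 nM, with an expected range of 11000 nM to 45000 nM.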

Compound 4, half-maximal cytotoxic concentration: > 20000 nM
Compound 4 gave a limit, no number (the forecaster's own chance of this, stated with the estimate: 85%); the middle value lies beyond the limit too.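

Among the compounds shown here, compound 1 and compound 4 both stop at a limit in this assay, and no step between them can be read. The compounds shown leave open where any of them truly stands, and whether oxetan-3-yl and pyridin-3-yl on that oxygen differ at all in this test: the limit of > 20000 nM in this assay, at which 4 of the 4 values shown sit.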